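The compounds below may be only part of what the source reports. "The series", "measured", "known", "first", "only" and "open" are said of these compounds alone.

Measured so far in a functional assay on COLO 205 cells (Homo sapiens) for inhibition, read by sulforhodamine B assay, with a stated time of 48 h, tested at 50 uM; a higher number here means more inhibition of growth at the concentration tested, a lower number less inhibition of growth
- compound 1 `COc1ccc(/C=C/C(=O)/C=C/c2ccc(OCc3cn(CCCCCOc4cc(=O)oc5ccccc45)nn3)c(OC)c2)cc1OC` gives 43% of inhibition
- compound 2 `COc1ccc(/C=C/C(=O)/C=C/c2ccc(OCc3cn(CCCCCOc4cc(=O)oc5ccccc45)nn3)c(OC)c2)cc1` gives 30% of inhibition

Of these two numbers, compound 2 holds the lower one, with compound 1 above it. For the measured compounds named here, the only measured step is a number 13 percentage points lower from compound 1 to compound 2 (beyond the scatter) with hydrogen in place of methoxy on an aromatic carbon.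

The next compound is compound 3 `COc1ccccc1/C=C/C(=O)/C=C/c1ccc(OCc2cn(CCCCCOc3cc(=O)oc4ccccc34)nn2)c(OC)c1` which has the same atoms as compound 2, joined differently. The change is 2-methoxyphenyl in place of 4-methoxyphenyl on a double-bonded chain carbon bound to a double-bonded chain carbon and it puts 2-methoxyphenyl in place of 4-methoxyphenyl on a double-bonded chain carbon bound to a double-bonded chain carbon.

Going by the values given here, no measured pair shows this kind of swap, so the evidence is thin. The nearest guide is a number 13 percentage points lower from compound 1 to compound 2 (beyond the scatter) where a methoxy group is lost outright. Here none is lost, so in this assay a step smaller than that one is expected, with no direction favoured. The estimate amounts to a number 2 percentage points higher from compound 2 to compound 3 (within the scatter) as an expected change and no more. For compound 3 the expected value is 32% with an estimated range from 18% to 46% in this measurement.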

Compound 3, percent growth inhibition at one concentration: 30%
Estimate against measurement, compound 3: 2 percentage points above; the measured number falls inside the stated range.
By their numbers in this assay, from the lowest: compounds 2 and 3 (each within the scatter of the next); then compound 1.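

In this assay, 2-methoxyphenyl in place of 4-methoxyphenyl on a double-bonded chain carbon bound to a double-bonded chain carbon gives no change at the digits printed from compound 2 to compound 3 (within the scatter), so at this place the test cannot tell these two single-methoxy arrangements apart. The change from the 3,4-dimethoxyphenyl group to 2-methoxyphenyl at the same place gives a number 13 percentage points lower from compound 1 to compound 3 (beyond the scatter), so compounds 2 and 3 both sit under compound 1, and among these three compounds, the two with one methoxy group on this ring stand together, with no compound going against that. Nothing measured here explains either step.

Going by these compounds, it remains open whether the higher number of compound 1 needs two methoxy groups in particular or would also appear with another pair, such as 2,4-dimethoxyphenyl. Also open, on these data alone, is how this place responds to groups of a different kind on the same ring, such as a hydroxy group, a dimethylamino group or a fluorine atom, or to a plain phenyl ring carrying no methoxy group at all.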